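Fluoroaryl variation at the fused core: pharmacokinetic notes

The source may hold more compounds than are shown below. What is called first, only, known or untested is meant among the compounds shown, and "the series" means these compounds.

Measured compounds:
compound 1, `O=C(Nc1ccc(F)c(-c2nc3ncc(-c4ccccc4F)cc3[nH]2)c1)N1CCCC1`: 4870 ng.h/mL
compound 2, `O=C(Nc1ccc(F)c(-c2nc3ncc(-c4cncc(F)c4)cc3[nH]2)c1)N1CCCC1`: 1560 ng.h/mL
compound 3, `O=C(Nc1ccc(F)c(-c2nc3ncc(-c4cccnc4F)cc3[nH]2)c1)N1CCCC1`: 30900 ng.h/mL

All three were read in an ADME assay on the whole organism (Mus musculus, strain Swiss Webster) for pharmacokinetics, read by LC-MS, at a dose of 50 mg/kg by the oral route; a lower number here means less compound in the circulation, a higher number more compound in the circulation at the dose given. Compound 3 stands highest of the three numbers: the nearest is compound 1, with a 6.3-fold higher number from compound 1 to compound 3 (0.80 log units; beyond the scatter), and the furthest is compound 2, with a 20-fold higher number from compound 2 to compound 3 (1.30 log units; beyond the scatter). Between the two lower compounds the step is a 3.1-fold lower number from compound 1 to compound 2 (0.49 log units; beyond the scatter).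

Compound 4, `O=C(Nc1ccc(F)c(-c2nc3ncc(-c4ccc(F)cc4)cc3[nH]2)c1)N1CCCC1`, is not yet measured. It differs from compound 3 by 4-fluorophenyl in place of 2-fluoropyridin-3-yl on an aromatic carbon. Among the compounds with values here, the step that bears on this change is the one from compound 1 to compound 3, where the ring of carbon only gave way to the ring with one nitrogen and the number rose beyond the scatter. Within the data shown here, compound 4 reverses that ring type, though the fluorine also moves, and no measured pair isolates that move. A step downward beyond the scatter is therefore expected, of modest size: a 6.9-fold lower number from compound 3 to compound 4 (0.84 log units; beyond the scatter). Compound 4 is expected to give 4500 ng.h/mL, within a range of 1500 ng.h/mL to 13000 ng.h/mL.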

Compound 4, area under the concentration-time curve: 10200 ng.h/mL
For compound 4 the middle estimate is 2.3-fold (0.36 log units) below the measured one; measured number inside the range.
By their numbers in this assay, from the lowest: compound 2; then compound 1; then compound 4; then compound 3.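

In this assay, 4-fluorophenyl falls short of 2-fluoropyridin-3-yl (a 3.0-fold lower number from compound 3 to compound 4 (0.48 log units; beyond the scatter)) yet exceeds 5-fluoropyridin-3-yl (a 6.5-fold higher number from compound 2 to compound 4 (0.82 log units; beyond the scatter)), so ring type alone does not order this position: the two rings with one nitrogen stand at the top and the bottom of the four compounds, with the two rings of carbon only in the middle. Within the data shown here, the two rings of carbon only also separate (a 2.1-fold higher number from compound 1 to compound 4 (0.32 log units; beyond the scatter)), which gives the first pair in which the fluorine moves while the ring type stays the same. No measurement at hand explains these differences.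

A plain phenyl or pyridin-3-yl without fluorine would show what the fluorine itself contributes, and an amine or a carboxylic acid on the ring remains untested territory in the compounds shown. Exposure after a single oral dose also does not separate uptake from clearance.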